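Acetylation of the Side-Chain Hydroxyl and Plasma Stability

The source may hold more compounds than are shown below. What is called first, only, known or untested is meant among the compounds shown, and "the series" means these compounds.

Compound 1 `C[C@@H](O)[C@H]1C(=O)N2C3=C(S[C@@H]4CN[C@@H](C4)C(=O)Nc4cccc(c4)C(=O)OCOCOC3=O)[C@H](C)[C@H]12` stands highest of the two compounds measured in an ADME assay on a cell-free system (plasma, Homo sapiens) for metabolic stability, read by LC-MS, with a stated time of 60 min, at 37 degrees C, tested at 50 uM (on this read-out lower numbers stand for a less stable compound and higher numbers for a more stable compound), where compound 1 gives 60%. Compound 2 `C[C@@H](O)[C@H]1C(=O)N2C(C(=O)OCc3oc(=O)oc3C(C)(C)C)=C(S[C@@H]3CN[C@H](C(=O)Nc4cccc(C(=O)OCc5oc(=O)oc5C(C)(C)C)c4)C3)[C@H](C)[C@H]12` lies far beyond the scatter below it, with compound 2 giving 10% in this assay. Compound 3 `CC(=O)O[C@H](C)[C@H]1C(=O)N2C3=C(S[C@@H]4CN[C@@H](C4)C(=O)Nc4cccc(c4)C(=O)OCOCOC3=O)[C@H](C)[C@H]12` differs from compound 1 by acetyl in place of hydrogen on an oxygen on a saturated carbon. Within the data shown here, no measured pair shows this change, so its effect in this assay is not known from these data. A moderate fall in the compound remaining is expected, and the expected step is a number 20 percentage points lower from compound 1 to compound 3 (beyond the scatter). Compound 3 is therefore estimated at 40%, within 15% to 65%.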

Compound 3, percent of the compound remaining in the plasma assay: 30%
Compound 3: middle estimate off by 10 percentage points, on the high side, and the stated range covers the measured number.
By their numbers in the plasma assay, from the lowest: compound 2; then compound 3; then compound 1.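

Acetyl in place of hydrogen on the oxygen on a saturated carbon, the change from hydroxy to acetoxy, gives in the plasma assay a number 30 percentage points lower from compound 1 to compound 3 (beyond the scatter), so this position does bear on the read-out. In a physicochemical assay for metabolic stability, read by LC-MS, in phosphate buffer, with a stated time of 3 h, at pH 7.4, tested at 50 uM (a lower number here means that less of the compound is left, a higher number that more of the compound is left), compound 1 gives > 95%, which is a limit of the assay. In the physicochemical assay compound 3 gives > 95%, also a limit, so the step there cannot be read: the limit of > 95% in the physicochemical assay, at which 2 of the 2 values shown sit.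

As far as these compounds go, whether a longer chain such as butyryl on this oxygen, or an amine in place of the hydroxy, would shift the plasma assay remains open. So does whether acetyl would give a similar step on compound 2.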